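Aryl swap on the sulfonamide nitrogen of compound 2

The compounds below may be only part of what the source reports. "The series", "measured", "known", "first", "only" and "open" are said of these compounds alone.

Among the compounds with values here, only two compounds have numbers so far. In a functional assay on K562 cells (Homo sapiens) for inhibition, read by CCK-8 assay, with a stated time of 72 h (a lower number here means a stronger inhibitor, a higher number a weaker inhibitor), compound 1 `O=C(/C=C/c1cccnc1)NCCCc1ccc(S(=O)(=O)Nc2ccccc2)cc1` gives 4900 nM as its value. Compound 2 `Cc1ccccc1NS(=O)(=O)c1cccc(CCCCCCNC(=O)/C=C/c2cccnc2)c1` gives 0.456 nM in this assay and so holds the lower of the two numbers, with a gap well beyond the scatter of repeat measurements. The two compounds differ in more than one place, so that gap cannot be tied to any single change.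

Compound 3 `O=C(/C=C/c1cccnc1)NCCCCCCc1cccc(S(=O)(=O)Nc2ccc(F)c(Cl)c2)c1` keeps the rest of compound 2 and carries 3-chloro-4-fluorophenyl in place of 2-methylphenyl on a sulfonamide nitrogen. Within the data shown here, no measured pair isolates this position, so the expectation rests on the structural change alone. A small rise in the number is expected, estimated at a 2.2-fold higher number from compound 2 to compound 3 (0.34 log units; beyond the scatter) and possibly not beyond the scatter. In this assay the expected value for compound 3 is 1 nM with an estimated range of 0.2 nM to 8 nM for the measurement.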

Compound 3, half-maximal inhibitory concentration: 5.31 nM
Compound 3: the middle estimate sits 5.3-fold (0.73 log units) below what was measured, within the range that was stated.
By their numbers in this assay, from the lowest: compound 2; then compound 3; then compound 1.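

In this assay, within the data shown here, the swap to 3-chloro-4-fluorophenyl in place of 2-methylphenyl on a sulfonamide nitrogen gives a 12-fold higher number from compound 2 to compound 3 (1.07 log units; beyond the scatter) and is the first step that can be tied to one place, so the aryl group on this nitrogen clearly bears on the number. The step is large, yet compound 3 at 5.31 nM shows that a phenyl ring carrying chlorine and fluorine on this nitrogen still keeps the number in the nanomolar range. This single pair cannot separate the loss of the methyl group from the entry of the two halogens, and no measurement at hand speaks to the origin of the step.

Still open, on these data alone, is which part of the swap carries the step, a question that an unsubstituted phenyl, 3-chlorophenyl or 4-fluorophenyl on this nitrogen would address. Equally open, as far as these compounds go, is how much of the gap between compound 1 and compound 2 belongs to the chain, which a longer chain on the otherwise unchanged core of compound 2 would begin to test, and how an aryl group bearing an amine or a carboxylic acid would fare here.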